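A few compounds are considered here, and "the series" means these few. Any claim that something is new, unique, unknown or untested is made for them only; others in the source may bear on it.

Series notes. Compound 1 `O=C(NCCCCl)Nc1ccc(I)cc1` carries the (3-chloropropyl)amino chain on the carbonyl of its core. In a functional assay on MCF7 cells (Homo sapiens) for antiproliferative activity, with a stated time of 48 h (a lower number here means a stronger inhibitor, a higher number a weaker inhibitor), compound 1 gives only a limit, > 100000 nM, and no number. Compound 2 `CC(C)(C)c1ccc(NC(=O)NCCCCl)cc1` gives 49000 nM in this assay and compound 3 `CCCCC(OC)c1cccc(NC(=O)NCCCCl)c1` gives 50000 nM in this assay. Within the data shown here, the one measured step, an at least 2.0-fold lower number from compound 1 to compound 2 (0.30 log units; that floor lies within the scatter), starts from a limit, so its size rests on the limit of > 100000 nM in this assay, at which 1 of the 3 values shown sits, rather than on a number for compound 1; the values of compound 2 and compound 3 lie within the scatter of each other.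

Compound 4 `C=CC(=O)Nc1ccc(I)cc1` is the next point. The change from compound 1 is vinyl in place of (3-chloropropyl)amino on a carbonyl carbon; iodo on the aromatic carbon is kept. Among the measured compounds shown here, no measured step touches this carbonyl carbon: the only step known, an at least 2.0-fold lower number from compound 1 to compound 2 (0.30 log units; that floor lies within the scatter), swaps a substituent on an aromatic carbon and says nothing about the chain on the carbonyl. The measured compounds therefore give no ground for a step in either direction beyond the scatter in this assay, and compound 1 itself sits at a limit. Compound 4 is expected near that level, estimated at 70000 nM with a range from 15000 nM to 300000 nM. The expected step is an at least 1.4-fold lower number from compound 1 to compound 4 (0.15 log units; that floor lies within the scatter). Pending the measurement, there is a real chance that only a limit is reported again.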

Compound 4, half-maximal inhibitory concentration: 17000 nM
The estimate for compound 4 lay 4.1-fold (0.61 log units) above the measured number; low and high end bracket the measured number.
By their numbers in this assay, from the lowest: compound 4; then compounds 2 and 3 (each within the scatter of the next). At a limit, above all of these: compound 1.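

Among these compounds, the carbonyl carbon, which no earlier step touched, now shows a measurable response in this assay: with iodo on the aromatic carbon kept, vinyl in place of (3-chloropropyl)amino gives an at least 5.8-fold lower number from compound 1 to compound 4 (0.76 log units; beyond the scatter). Compound 1 gives only a limit, > 100000 nM. Unlike the earlier step from that compound, which has a floor within the scatter, this one clears the scatter even as a floor, though its full size stays unknown and depends on a value that is not a number: the limit of > 100000 nM in this assay, at which 1 of the 4 values shown sits.

The compounds shown do not separate the gain of the vinyl double bond from the loss of the (3-chloropropyl)amino chain with its nitrogen and chlorine, and an ethyl group on the same carbonyl carbon would set the double bond apart from the rest of the change. They also leave open whether vinyl on the carbonyl carbon gives a step of similar size when tert-butyl stands in place of iodo on the aromatic carbon.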